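Replacing the aryl ketone by an anilide in the shared core

The compounds below may be only part of what the source reports. "The series", "measured", "known", "first", "only" and "open" are said of these compounds alone.

The measured compounds:
compound 1 `COc1cc(-c2nnc(SCC(=O)c3ccc(Cl)cc3)n2N)cc(OC)c1OC` — > 100000 nM
compound 2 `COc1cc(-c2nnc(SCC(=O)c3ccc(Br)cc3)n2N)cc(OC)c1OC` — 92500 nM
compound 3 `COc1cc(-c2nnc(SCC(=O)c3ccc(F)cc3)n2N)cc(OC)c1OC` — 90400 nM

All three share one core and differ only at the halogen on the aromatic ring of the ketone. In a functional assay on HepG2 cells (Homo sapiens) for antiproliferative activity, read by MTT assay, with a stated time of 48 h (a lower number here means a stronger inhibitor, a higher number a weaker inhibitor), compound 1 reaches only a limit, > 100000 nM, and not a number. Compound 2 gives 92500 nM in this assay, the higher of the two numbers shown, though its nearest neighbour compound 3, at 90400 nM, lies within the scatter of it; the step of a 1.0-fold lower number from compound 2 to compound 3 (0.01 log units; within the scatter) says as much. The steps of an at least 1.0-fold lower number from compound 1 to compound 2 (0.03 log units; that floor lies within the scatter) and an at least 1.1-fold lower number from compound 1 to compound 3 (0.04 log units; that floor lies within the scatter) start from a limit of > 100000 nM in this assay, at which 1 of the 3 values shown sits, and carry no more.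

Compound 4 `COc1cc(-c2nnc(SCC(=O)Nc3ccc(C)cc3)n2N)cc(OC)c1OC` is not yet measured. It differs from compound 2 in this way: (4-methylphenyl)amino in place of 4-bromophenyl on a carbonyl carbon. For the measured compounds named here, none of the measured steps touches this change; they swap one halogen for another and all sit within the scatter. Going by the values given here, the step of a 1.0-fold lower number from compound 2 to compound 4 (0.01 log units; within the scatter) in this assay is therefore only an expectation, set by no step of the same kind. Compound 4 is therefore estimated at 90000 nM, with a wide range from 25000 nM to 300000 nM.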

Compound 4, half-maximal inhibitory concentration: > 100000 nM
Compound 4 was reported as a limit; the forecaster's own chance of this, stated with the estimate: 40%; middle value at least 1.1-fold (0.04 log units) away from the limit.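

In this assay, for the compounds shown here, compound 4 gives > 100000 nM, which is a limit and not a number, so the first change at the carbonyl carbon itself, rather than at the halogen, brings no readable activity into view. Its steps, an at least 1.0-fold higher number from compound 2 to compound 4 (0.03 log units; that floor lies within the scatter) and an at least 1.1-fold higher number from compound 3 to compound 4 (0.04 log units; that floor lies within the scatter), give only floors, and the step from compound 1, with limits at both ends, cannot be read. The anilide therefore joins the ketones at the weak edge of what this assay can read: the limit of > 100000 nM in this assay, at which 2 of the 4 values shown sit.

Compound 4 also carries a methyl group where the ketones carry a halogen, so the compounds shown do not separate the effect of the amide hydrogen from that of the ring substituent. Open too, on these data alone, is how an anilide bearing a bromo group, a carboxylic acid or a longer chain on the carbonyl carbon would read.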